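The compounds below may be only part of what the source reports. "The series", "measured", "known", "first", "only" and "open" are said of these compounds alone.

Compound 3 `O=C(OC1(C(=O)Nc2ccc([N+](=O)[O-])cc2)CCCCC1)C(O)c1ccccc1` gives the lowest number of the three measured compounds in an ADME assay on WI-38 cells (Homo sapiens) for inhibition, read by MTT assay, with a stated time of 72 h (on this read-out lower numbers stand for stronger inhibition and higher numbers for weaker inhibition), namely 84.4 nM. Compound 1 `Cc1ccccc1C(=O)OC1(C(=O)Nc2ccc([N+](=O)[O-])cc2)CCCCC1` gives 352 nM in this assay, and compound 2 `O=C(OC1(C(=O)Nc2ccc([N+](=O)[O-])cc2)CCCCC1)c1ccccc1` gives 246 nM. Compound 4 `CC(=O)Oc1ccccc1C(=O)OC1(C(=O)Nc2ccc([N+](=O)[O-])cc2)CCCCC1` carries 2-acetoxyphenyl in place of hydroxy(phenyl)methyl on a carbonyl carbon. The measured steps that bear on this are the ones running the other way, where hydroxy(phenyl)methyl replaced an aromatic group on the carbonyl carbon: a 4.2-fold lower number from compound 1 to compound 3 (0.62 log units; beyond the scatter) and a 2.9-fold lower number from compound 2 to compound 3 (0.46 log units; beyond the scatter), both modest and beyond the scatter. Returning to an aromatic group is therefore expected to give a modest step upward in this assay, a 3.3-fold higher number from compound 3 to compound 4 (0.52 log units; beyond the scatter), landing near the numbers of compound 1 and compound 2. Compound 4 is thus estimated at 280 nM, within a range of 110 nM to 700 nM.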

Compound 4, half-maximal inhibitory concentration: 48.4 nM
Estimate against measurement, compound 4: 5.8-fold (0.76 log units) above; the whole stated range lies above it.
By their numbers in this assay, from the lowest: compounds 4 and 3 (each within the scatter of the next); then compounds 2 and 1 (each within the scatter of the next).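

In this assay an aromatic group on this carbonyl carbon does not by itself go with the higher numbers: acetoxy on an aromatic carbon gives a 7.3-fold lower number from compound 1 to compound 4 (0.86 log units; beyond the scatter) where methyl stood, and a 5.1-fold lower number from compound 2 to compound 4 (0.71 log units; beyond the scatter) where hydrogen stood. The 2-acetoxyphenyl and hydroxy(phenyl)methyl groups cannot be told apart here, with a 1.7-fold lower number from compound 3 to compound 4 (0.24 log units; within the scatter) lying within the scatter. The compounds shown leave open whether a hydroxy group, an amine or a carboxylic acid in place of acetoxy would give similar numbers. Nothing available explains these steps.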